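Phenyl for Methyl on the Core of Compound 2

A few compounds are considered here, and "the series" means these few. Any claim that something is new, unique, unknown or untested is made for them only; others in the source may bear on it.

Measured compounds:
compound 1, `Cc1nc(C#Cc2ccc(F)cc2)cs1`, in a functional assay on CHO cells for agonist activity at metabotropic glutamate receptor 5 (Homo sapiens), read by inositol phosphate accumulation; a higher number here means a weaker inhibitor, a lower number a stronger inhibitor: 2970 nM
compound 2, `Cc1nc(C#Cc2cccnc2)c(C)s1`, in this assay: 698 nM

Of the two measured compounds, compound 2 gives the lower number in this assay, and the gap to compound 1 lies beyond the usual scatter, so compound 2 is the stronger inhibitor of the pair. Compound 3, `Cc1nc(C#Cc2cccnc2)c(-c2ccccc2)s1`, keeps the core of compound 2 and differs from it in one place: phenyl in place of methyl on an aromatic carbon. Among the measured compounds shown here, no measured pair shows what this exchange does, so the direction of the step is open. A change of this size at that position is expected to move the number by a modest amount, and the estimated step of a 1.6-fold lower number from compound 2 to compound 3 (0.19 log units; within the scatter) is taken as a small improvement that may well fall within the scatter. Compound 3 is therefore expected to give about 450 nM in this assay, with a range from 90 nM to 2500 nM.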

Compound 3, half-maximal inhibitory concentration: > 10000 nM
Compound 3 was reported as a limit (the forecaster's own chance of this, stated with the estimate: 5%); at least 22-fold (1.34 log units) between middle value and limit.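

In this assay, phenyl in place of methyl on an aromatic carbon next to the ring sulfur gives an at least 14-fold higher number from compound 2 to compound 3 (1.15 log units; beyond the scatter). Among the compounds shown here, this is the first exchange measured at this position, and it shows that the position is far from indifferent to what it carries: with the core of compound 2 held fixed, going from methyl to phenyl alone leaves a much weaker inhibitor, a change well beyond the scatter. Compound 3 stands only as a limit of the assay, so the full size of the step stays unknown: the limit of > 10000 nM in this assay, at which 1 of the 3 values shown sits.

With the core of compound 2, only methyl and phenyl are shown on this carbon, so where an ethyl, a methoxy or an amine would fall stays open. What lies behind the rise is not shown by these data.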